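Working notes: 4-methylphenyl to 2-isopropylphenyl

This account rests on a few compounds, and the source may have more. Where it says the series, first, only, none or still open, it means among the compounds named here.

Measured in a functional assay on Jurkat cells (Homo sapiens) for inhibition, read by CCK-8 assay, with a stated time of 48 h; on this read-out higher numbers stand for weaker inhibition of growth and lower numbers for stronger inhibition of growth:
- compound 1 `CN1CCN(c2ccc(Nc3ncc(Cl)c(NCc4ccccc4)n3)nc2)CC1`: > 100000 nM (a limit)
- compound 2 `Cc1ccc(Nc2nc(Nc3ccc(N4CCN(C)CC4)cn3)ncc2Cl)cc1`: 30900 nM

For the measured compounds named here, compound 2, at 30900 nM, holds the only true number in this assay. Compound 1 stands at a limit, not a number: the limit of > 100000 nM in this assay, at which 1 of the 2 values shown sits.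

The next change leads to compound 3 `CC(C)c1ccccc1Nc1nc(Nc2ccc(N3CCN(C)CC3)cn2)ncc1Cl`: 2-isopropylphenyl in place of 4-methylphenyl on a nitrogen on an aromatic ring. In words, 2-isopropylphenyl stands in place of 4-methylphenyl on a nitrogen on an aromatic ring.

Going by the values given here, one measured step bears on this place, an at least 3.2-fold lower number from compound 1 to compound 2 (0.51 log units; beyond the scatter). It replaced benzyl, not one substituted phenyl with another, so it guides only loosely. No step beyond the scatter is therefore expected in this assay, in either direction. The expected step is a 1.2-fold lower number from compound 2 to compound 3 (0.09 log units; within the scatter). For compound 3 the estimated value is 25000 nM, with an expected range of 8000 nM to 90000 nM.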

Compound 3, concentration for 50% growth inhibition: 5140 nM
Compound 3: the middle estimate sits 4.9-fold (0.69 log units) above what was measured; the whole stated range lies above it.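

In this assay, for the compounds shown here, the group on this nitrogen still has room to move the number once an aromatic ring sits directly on it: 2-isopropylphenyl in place of 4-methylphenyl gives a 6.0-fold lower number from compound 2 to compound 3 (0.78 log units; beyond the scatter) in the first comparison of one substituted phenyl with another. Going from benzyl to 2-isopropylphenyl gives an at least 19-fold lower number from compound 1 to compound 3 (1.28 log units; beyond the scatter) and so adds to the earlier step from benzyl to 4-methylphenyl. That step is only a bound, as compound 1 stands at a limit and not at a number: the limit of > 100000 nM in this assay, at which 1 of the 3 values shown sits.

The two substituted phenyl groups differ both in the substituent and in its place on the ring, so 2-methylphenyl and 4-isopropylphenyl would be needed to separate the two. Also open, going by these compounds, is how this position responds to a group other than a plain hydrocarbon, such as an amine or a carboxylic acid on the phenyl ring.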